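Quinolinyl Attachment Point Shift in a Sulfonylurea Series

This account rests on a few compounds, and the source may have more. Where it says the series, first, only, none or still open, it means among the compounds named here.

Compound 1 `O=C(NC1CCCCC1)NS(=O)(=O)N1CCC(CCNC(=O)C(F)(F)F)CC1` and compound 2 `O=C(NC1CCCCC1)NS(=O)(=O)N1CCC(CCNC(=O)c2ccc3ccccc3n2)CC1` were tested in a functional assay on the whole organism (blood) with Rattus norvegicus as the target, with stated times of 24 h and 1 h, at a dose of 5 mg/kg by the intraperitoneal route; a higher number here means a stronger effect of the compound at the dose given, a lower number a weaker effect. Compound 1 gives 13%, and compound 2 gives 11%; the step of a number 2 percentage points lower from compound 1 to compound 2 (within the scatter) stayed within the scatter, so compound 2, holding the lowest of the two numbers, is not set apart from compound 1. Compound 3 `O=C(NC1CCCCC1)NS(=O)(=O)N1CCC(CCNC(=O)c2ccnc3ccccc23)CC1` differs from compound 2 only in quinolin-4-yl in place of quinolin-2-yl on a carbonyl carbon. Among the measured compounds shown here, the sole measured step at this carbonyl carbon, trifluoromethyl to quinolin-2-yl, stayed within the scatter, so the expected step is a number 1 percentage points higher from compound 2 to compound 3 (within the scatter), nothing beyond the scatter. Compound 3 is estimated at 12%, ranging from 3% to 24%.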

Compound 3, a percentage reported as activity, at one dose (the size of the read-out at that dose, not a potency): 16%
Compound 3: the middle estimate sits 4 percentage points below what was measured, within the range that was stated.
By their numbers in this assay, from the lowest: compounds 2, 1 and 3 (each within the scatter of the next).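

In this assay, quinolin-4-yl in place of quinolin-2-yl on the carbonyl carbon gives a number 5 percentage points higher from compound 2 to compound 3 (within the scatter), and quinolin-4-yl in place of trifluoromethyl gives a number 3 percentage points higher from compound 1 to compound 3 (within the scatter). The attachment point of the quinolinyl group therefore adds a second kind of change at this position that does not set the compounds apart, and all three stand within the scatter of one another. No evidence available here bears on this result. From the compounds shown here alone, whether a phenyl group or a longer chain on this carbonyl carbon would give a step beyond the scatter remains open.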